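Switching a sulfonyl bridge for a ketone at the ortho position

The source may report more compounds than this note shows. Statements on the series, on what has been measured and on what is new or still open speak of the compounds shown alone.

Measured compounds:
compound 1, `Cc1c(Cc2ccccc2S(=O)(=O)c2ccc(Cl)cc2)c2c(n1CC(=O)O)CCNC2=O`, 8.5 nM
compound 2, `Cc1c(Cc2ccccc2S(=O)(=O)N(C)Cc2ccccc2)c2c(n1CC(=O)O)CCNC2=O`, 26 nM

The two measured compounds were tested in a functional assay on CHO.K1 cells for antagonist activity at prostaglandin D2 receptor 2 (Homo sapiens), read by GTPgammaS binding, with a stated time of 1 h; a higher number here means a weaker inhibitor, a lower number a stronger inhibitor. Compound 1 gives 8.5 nM, the lower of the two numbers, and compound 2 gives 26 nM. Among the measured compounds shown here, the one measured step, a 3.1-fold higher number from compound 1 to compound 2 (0.49 log units; beyond the scatter), comes from putting benzyl(methyl)amino in place of 4-chlorophenyl on the sulfonyl sulfur, so a change at the group hanging off the sulfonyl costs a modest amount.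

Compound 3, `Cc1c(Cc2ccccc2C(=O)c2ccccc2)c2c(n1CC(=O)O)CCNC2=O`, has not been measured. It differs from compound 1 in this way: benzoyl in place of (4-chlorophenyl)sulfonyl on an aromatic carbon. Here the sulfonyl itself is exchanged, not just the group on it, and the chlorine is gone as well. For the measured compounds named here, no measured pair addresses this exact change; the step from compound 1 to compound 2 shows only that altering the group at this position is felt, and modestly.

On that basis compound 3 is expected to give a somewhat higher number in this assay than compound 1, estimated as a 2.9-fold higher number from compound 1 to compound 3 (0.47 log units; beyond the scatter). For compound 3 the estimate is 25 nM, with a likely range from 8 nM to 80 nM.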

Compound 3, half-maximal inhibitory concentration: 810 nM
Compound 3: middle estimate off by 32-fold (1.51 log units), on the low side; measured number above the stated range.
By their numbers in this assay, from the lowest: compound 1; then compound 2; then compound 3.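

Exchanging (4-chlorophenyl)sulfonyl for benzoyl on the aromatic carbon gives a 95-fold higher number from compound 1 to compound 3 (1.98 log units; beyond the scatter) in this assay, a large step, whereas replacing only the group on the sulfonyl sulfur gave a 3.1-fold higher number from compound 1 to compound 2 (0.49 log units; beyond the scatter). The two steps together show that the group on the sulfur can differ widely at a modest cost, while this single exchange, which removes both the sulfonyl and the chlorine, costs far more, so the position is much less forgiving than the first pair suggested. No measurement of any property of these groups is available to account for the size of this step.

The compounds shown do not separate the part played by the carbonyl in place of the sulfonyl from the part played by the lost chlorine, and a 4-chlorobenzoyl group or a phenylsulfonyl group would tell the two apart. Also open, as far as these compounds go, is whether another link in this place, such as a methylene or an ether oxygen carrying the same 4-chlorophenyl group, would bring the number back towards that of compound 1 at 8.5 nM.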